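The source may report more compounds than this note shows. Statements on the series, on what has been measured and on what is new or still open speak of the compounds shown alone.

Measured in a physicochemical assay for solubility; a lower number here means a less soluble compound, a higher number a more soluble compound:
- Compound 1 `COc1cc(OC)c(/C=C/S(=O)(=O)Nc2ccc(OC)c(NC(C)C(=O)O)c2)c(OC)c1`: 10000 ug/mL
- Compound 2 `COc1cc(OC)c(/C=C/S(=O)(=O)Nc2ccc(OC)c(NC(C)(C)C(=O)O)c2)c(OC)c1`: 10000 ug/mL
- Compound 3 `COc1cc(OC)c(/C=C/S(=O)(=O)Nc2ccc(OC)c(NC(C(=O)O)c3ccc(F)cc3)c2)c(OC)c1`: 10000 ug/mL

Compound 2, at 10000 ug/mL, stands level with compounds 1 and 3. The next compound to consider is compound 4 `COc1cc(OC)c(/C=C/S(=O)(=O)Nc2ccc(OC)c(NC(C(=O)O)c3ccc(Br)cc3)c2)c(OC)c1`, and the change that leads to it is (4-bromophenyl)(carboxy)methyl in place of 1-carboxy-1-methylethyl on a nitrogen on an aromatic ring. In short, (4-bromophenyl)(carboxy)methyl takes the place of 1-carboxy-1-methylethyl on a nitrogen on an aromatic ring.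

The closest measured precedent is the step of no change at the digits printed from compound 2 to compound 3 (within the scatter), which puts carboxy(4-fluorophenyl)methyl on that same nitrogen. The other two steps, no change at the digits printed from compound 1 to compound 2 (within the scatter) and no change at the digits printed from compound 1 to compound 3 (within the scatter), are equally small. For the measured compounds named here, none of the three steps moves the read-out, but no measured compound carries bromine, so that part of the change remains untested. The expectation in this assay is therefore no shift beyond the scatter, and the step is expected to be no change at the digits printed from compound 2 to compound 4 (within the scatter). For compound 4 the estimated value is 10000 ug/mL, with an expected range from 5000 ug/mL to 12000 ug/mL.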

Compound 4, solubility: 10000 ug/mL
Estimate against measurement, compound 4: no gap at the digits printed, within the range that was stated.
By their numbers in this assay, from the lowest: compounds 1, 2, 3 and 4 (each within the scatter of the next).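

In this assay, for the compounds shown here, the first compound with bromine fits the level set by the others: bromo in place of fluoro on an aromatic carbon gives no change at the digits printed from compound 3 to compound 4 (within the scatter). On the nitrogen on an aromatic ring, (4-bromophenyl)(carboxy)methyl, with 11 heavy atoms where 1-carboxy-1-methylethyl has 6, gives no change at the digits printed from compound 2 to compound 4 (within the scatter). Likewise, 4-bromophenyl in place of methyl on the saturated chain carbon gives no change at the digits printed from compound 1 to compound 4 (within the scatter), so this position has now taken methyl, 4-fluorophenyl and 4-bromophenyl with no step beyond the scatter.

All four compounds keep the carboxylic acid, so the compounds shown leave open what a methyl ester or a primary amide in its place would give. No evidence is available on why the read-out stays level across these changes.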